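Methoxymethyl in place of hydroxymethyl: series notes

The source may hold more compounds than are shown below. What is called first, only, known or untested is meant among the compounds shown, and "the series" means these compounds.

Values in an ADME assay on HEp-2 cells (Homo sapiens) for cytotoxicity (on this read-out lower numbers stand for higher toxicity in this test and higher numbers for lower toxicity in this test), are as follows:
- compound 1 `CC(C)CCn1c(Cn2c(=O)n(C(C)C)c3ccccc32)nc2c(CN)cccc21` gives 7000 nM
- compound 2 `CC(C)CCn1c(Cn2c(=O)n(C(C)C)c3ccccc32)nc2ccc(C(=O)O)cc21` gives 125000 nM
- compound 3 `CC(C)CCn1c(Cn2c(=O)n(C(C)C)c3ccccc32)nc2c(CO)cccc21` gives 22000 nM

Compound 3 holds the second highest of the three numbers, above compound 1 and below compound 2. The next analogue, compound 4 `COCc1cccc2c1nc(Cn1c(=O)n(C(C)C)c3ccccc31)n2CCC(C)C`, differs from compound 3 by methyl in place of hydrogen on an oxygen on a saturated carbon and this reads as methyl in place of hydrogen on an oxygen on a saturated carbon, or hydroxymethyl to methoxymethyl. Going by the values given here, the one measured step bearing on this is a 3.1-fold higher number from compound 1 to compound 3 (0.50 log units; beyond the scatter) for hydroxy in place of amino on a saturated chain carbon bound to an aromatic carbon. Among the compounds with values here, it is modest and exchanges a different group, so no measured step covers methyl on that oxygen. In this assay the expected change is small, slightly toward a lower number and not beyond the scatter. The step expected is a 1.2-fold lower number from compound 3 to compound 4 (0.09 log units; within the scatter) and it remains an estimate. The estimated value for compound 4 is 18000 nM (expected range 8000 nM to 45000 nM).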

Compound 4, half-maximal cytotoxic concentration: 26700 nM
The estimate for compound 4 lay 1.5-fold (0.17 log units) below the measured number; measured number inside the range.
By their numbers in this assay, from the lowest: compound 1; then compounds 3 and 4 (each within the scatter of the next); then compound 2.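

In this assay, methyl on the oxygen gives a 1.2-fold higher number from compound 3 to compound 4 (0.08 log units; within the scatter) and so leaves the read-out unchanged within the scatter: at this position, hydroxymethyl and methoxymethyl cannot be told apart. Methoxy in place of amino gives a 3.8-fold higher number from compound 1 to compound 4 (0.58 log units; beyond the scatter) and, with the hydroxy step, leaves compound 1 with the amine as the lowest of the three compounds at this position. No measurement bearing on the cause of either step is available.

As far as these compounds go, whether an ethyl group or a longer chain on that oxygen would also leave the read-out unchanged stays open.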